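This account rests on a few compounds, and the source may have more. Where it says the series, first, only, none or still open, it means among the compounds named here.

Measured compounds:
compound 1 `CNc1cc(Nc2ncc3c(n2)N(C)C(=O)N(c2cc(NC(=O)c4cccc(C(F)(F)F)c4)ccc2C)C3)ccc1C`, 19 nM
compound 2 `Cc1ccc(Nc2ncc3c(n2)N(C)C(=O)N(c2cc(NC(=O)c4cccc(C(F)(F)F)c4)ccc2C)C3)cc1N`, 3 nM
compound 3 `CNc1nc(Nc2ccc(C)c(N)c2)ncc1C(=O)Nc1cc(NC(=O)c2cccc(C(F)(F)F)c2)ccc1C`, 14 nM

These values come from a functional assay on K562 cells (Homo sapiens) for antiproliferative activity, read by CellTiter-Glo and CCK-8 assay, with a stated time of 72 h; a lower number here means a stronger inhibitor of growth, a higher number a weaker inhibitor of growth. Compound 2 and compound 1 share a core and differ only in one spot: methyl in place of hydrogen on a nitrogen on an aromatic ring. That change gave a 6.3-fold higher number from compound 2 to compound 1 (0.80 log units; beyond the scatter). Compound 3 rests on a different core; the difference between the two cores is not broken down here. Compound 4 `Cc1ccc(Nc2ncc(C(=O)Nc3cc(NC(=O)c4cccc(C(F)(F)F)c4)ccc3C)c(N(C)C)n2)cc1N` is the untested member of the set, and it differs from compound 3 by methyl in place of hydrogen on a nitrogen on an aromatic ring. The place is not identical in the two cases: in the earlier pair the nitrogen's other neighbour is an aromatic carbon only, whereas in compound 3 the nitrogen also carries a saturated chain carbon, so this is the same kind of change rather than the same change. In this assay a step of a 3.9-fold higher number from compound 3 to compound 4 (0.59 log units; beyond the scatter) is expected, resting on the weakening seen in a 6.3-fold higher number from compound 2 to compound 1 (0.80 log units; beyond the scatter). Compound 4 is therefore estimated at 55 nM, likely between 15 nM and 200 nM.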

Compound 4, concentration for 50% growth inhibition: 1210 nM
For compound 4 the middle estimate is 22-fold (1.34 log units) below the measured one; measured number outside the range, above it.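

In this assay, methyl in place of hydrogen on the nitrogen on the aromatic ring gave an 86-fold higher number from compound 3 to compound 4 (1.94 log units; beyond the scatter). The change raised the number on both cores, but its size did not carry over: the same change on two cores in this assay, a 6.3-fold higher number (0.80 log units; beyond the scatter) from compound 2 to compound 1 and an 86-fold higher number (1.94 log units; beyond the scatter) from compound 3 to compound 4, 14-fold (1.14 log units) apart, beyond the scatter of two such steps. The step on one core therefore did not give the size of the step on the other, but two pairs, whose nitrogens also have different neighbours, do not show what sets this gap or how the change would behave on further cores.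

From the compounds shown here alone, it remains open how an ethyl group or a longer chain on that nitrogen would compare with the methylamino and dimethylamino groups of compound 3 and compound 4.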